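This account rests on a few compounds, and the source may have more. Where it says the series, first, only, none or still open, it means among the compounds named here.

Of the compounds shown here, three have been measured in an assay on isolated protein for inhibition of Rho-associated protein kinase 2 (Homo sapiens); a higher number here means a weaker inhibitor, a lower number a stronger inhibitor. Compound 1 `Nc1nccc(-c2ccc3nc(C4COc5ccc(F)cc5C4)[nH]c3c2)n1` gives 6 nM. Compound 2 `COC(=O)c1ccc2c(c1)CC(c1nc3ccc(-c4ccnc(N)n4)cc3o1)CO2`, in the same assay, gives 24 nM. Compound 3 `Cc1[nH]ncc1-c1ccc2nc(C3COc4ccccc4C3)[nH]c2c1` gives 9 nM.

Compound 3 thus holds the second highest of the three numbers. Its number and that of compound 1 lie within the usual scatter of each other, so nothing can be said about which of the two is the stronger inhibitor. Compound 2 gives a higher number than compound 3, and that gap lies beyond the scatter.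

Compound 4 `c1ccc2c(c1)CC(c1nc3ccc(-c4ccncc4)cc3[nH]1)CO2` has not been measured. It differs from compound 3 in one place: pyridin-4-yl in place of 5-methyl-1H-pyrazol-4-yl on an aromatic carbon. For the measured compounds named here, no pair of measured compounds differs by exactly this change, so its effect cannot be read from the numbers above. Going by the values given here, the expectation is a modest step toward a higher number, a 2.8-fold higher number from compound 3 to compound 4 (0.44 log units; beyond the scatter), with room for no step at all. For compound 4 the estimate in this assay is 25 nM, within a range from 8 nM to 80 nM.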

Compound 4, half-maximal inhibitory concentration: 2 nM
Beside the measured number, compound 4's estimate is 13-fold (1.10 log units) above it; the measured number lies below the stated range.
By their numbers in this assay, from the lowest: compound 4; then compounds 1 and 3 (each within the scatter of the next); then compound 2.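

For the compounds shown here, at this aromatic carbon, the one direct comparison in this assay shows that replacing 5-methyl-1H-pyrazol-4-yl with pyridin-4-yl gives a 4.5-fold lower number from compound 3 to compound 4 (0.65 log units; beyond the scatter), a change that lies beyond the usual scatter. The group at this position therefore need not carry a hydrogen-bond donor for the number to stay low, at least on the core of compound 3. Nothing in the data explains why the number falls with this exchange.

Still open, as far as these compounds go, is whether the ring nitrogen of pyridin-4-yl matters, which could be tested at the same carbon with a plain phenyl ring or with pyridin-3-yl, where the nitrogen sits elsewhere in the ring. From the compounds shown here alone, it is also open whether the same exchange would lower the number on a different core, such as that of compound 2.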